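Methyl in place of methoxy on the aromatic ring

The source may hold more compounds than are shown below. What is called first, only, known or untested is meant among the compounds shown, and "the series" means these compounds.

Compound 3 `COc1ccc(N2C(=O)[C@H]3[C@H](ON4[C@@H]3C(=O)N(C)[C@@]43C[C@H](C)CC[C@H]3C(C)C)C2=O)cc1` gives the lowest number of the three in a functional assay, read by spectrophotometry, with a stated time of 2 h (on this read-out higher numbers stand for weaker inhibition and lower numbers for stronger inhibition), at 480 ug/mL. Compound 1 `CC(C)[C@@H]1CC[C@@H](C)C[C@@]12N(C)C(=O)[C@@H]1[C@H]3C(=O)N(c4ccccc4)C(=O)[C@H]3ON12` gives 2250 ug/mL and compound 2 `CC(C)[C@@H]1CC[C@@H](C)C[C@@]12N(C)C(=O)[C@@H]1[C@H]3C(=O)N(c4ccc(Cl)cc4)C(=O)[C@H]3ON12` gives 2000 ug/mL. The measured steps are a 4.7-fold lower number from compound 1 to compound 3 (0.67 log units; beyond the scatter), a 4.2-fold lower number from compound 2 to compound 3 (0.62 log units; beyond the scatter) and a 1.1-fold lower number from compound 1 to compound 2 (0.05 log units; within the scatter). Compound 4 `Cc1cccc(N2C(=O)[C@H]3[C@H](ON4[C@@H]3C(=O)N(C)[C@@]43C[C@H](C)CC[C@H]3C(C)C)C2=O)c1` differs from compound 3 by 3-methylphenyl in place of 4-methoxyphenyl on an amide-type nitrogen in a ring. Within the data shown here, both steps that reached compound 3 involved the methoxy group, and no measured step shows a methyl on this ring, so a move back toward the numbers of compound 1 and compound 2 is expected in this assay, though its size is uncertain. The expected change is a 3.1-fold higher number from compound 3 to compound 4 (0.49 log units; beyond the scatter). Compound 4 is therefore estimated at 1500 ug/mL, between 600 ug/mL and 3000 ug/mL.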

Compound 4, half-maximal inhibitory concentration: 2700 ug/mL
Compound 4: the middle estimate sits 1.8-fold (0.26 log units) below what was measured; the measured number falls inside the stated range.
By their numbers in this assay, from the lowest: compound 3; then compounds 2, 1 and 4 (each within the scatter of the next).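

In this assay the change to 3-methylphenyl on the amide-type nitrogen in a ring gives a 5.6-fold higher number from compound 3 to compound 4 (0.75 log units; beyond the scatter) and so does not keep the lower number that came with the 4-methoxyphenyl group. Alongside a 1.4-fold higher number from compound 2 to compound 4 (0.13 log units; within the scatter) and a 1.2-fold higher number from compound 1 to compound 4 (0.08 log units; within the scatter) this leaves the 4-methoxyphenyl group alone in standing apart from the other three aryl groups at this position. Nothing measured here accounts for that difference. The compounds shown do not separate the change of group from the change of its place on the ring. They also leave open whether an ethoxy group or an amine on the ring would keep the lower number of compound 3.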